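The source may hold more compounds than are shown below. What is called first, only, known or untested is meant among the compounds shown, and "the series" means these compounds.

In a functional assay on MCF7 cells (Homo sapiens) for cytotoxicity, read by sulforhodamine B assay, with a stated time of 3 days (on this read-out lower numbers stand for stronger inhibition and higher numbers for weaker inhibition), compound 2 `O=[N+]([O-])c1ccc(S(=O)(=O)N2CC(n3cnc4c(Cl)nc(Cl)nc43)OCc3ccccc32)cc1` gives 355 nM, the lowest of the two numbers on hand, while compound 1 `Nc1ccccc1S(=O)(=O)N1CC(n2cnc3c(Cl)nc(Cl)nc32)OCc2ccccc21` gives 820 nM. Compound 3 `O=S(=O)(c1ccccc1NO)N1CC(n2cnc3c(Cl)nc(Cl)nc32)OCc2ccccc21` carries 2-(hydroxyamino)phenyl in place of 4-nitrophenyl on a sulfonyl sulfur. For the measured compounds named here, the one measured step that bears on this change, a 2.3-fold lower number from compound 1 to compound 2 (0.36 log units; beyond the scatter), runs in the opposite direction, and the group entering compound 3 resembles the 2-aminophenyl of compound 1 more than the 4-nitrophenyl it replaces. The expected step, a 2.0-fold higher number from compound 2 to compound 3 (0.29 log units; within the scatter), is therefore a modest rise back toward the number of compound 1. Compound 3 is estimated at 700 nM, within a range from 300 nM to 1600 nM.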

Compound 3, half-maximal inhibitory concentration: 1530 nM
For compound 3 the middle estimate is 2.2-fold (0.34 log units) below the measured one; the range from low to high includes it.
By their numbers in this assay, from the lowest: compound 2; then compounds 1 and 3 (each within the scatter of the next).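

In this assay, 2-(hydroxyamino)phenyl in place of 4-nitrophenyl on the sulfonyl sulfur gives a 4.3-fold higher number from compound 2 to compound 3 (0.63 log units; beyond the scatter), so this change loses activity. Hydroxy in place of hydrogen on the nitrogen on an aromatic ring gives a 1.9-fold higher number from compound 1 to compound 3 (0.27 log units; within the scatter), so the added hydroxy separates compound 3 from compound 1 by no more than the usual scatter. Nothing on hand explains either step. Going by these compounds, because the two groups also differ in substitution pattern, whether 4-aminophenyl or 2-nitrophenyl would separate the effect of the nitrogen group from that of its placement remains open.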